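Swapping a methoxyphenyl for a dimethylphenyl in a diacylhydrazine

A few compounds are considered here, and "the series" means these few. Any claim that something is new, unique, unknown or untested is made for them only; others in the source may bear on it.

Of the compounds shown here, two sharing one diacylhydrazine core have been measured. Compound 1 `COc1cccc(C(=O)NN(C(=O)c2ccccc2Cl)C(C)(C)C)c1` gives 52.5 nM in an assay on cells for agonist activity at ecdysone receptor (Bombyx mori), read by a luciferase reporter, with a stated time of 24 h; a lower number here means that less compound is needed, a higher number that more compound is needed for the effect. Compound 2 `COc1ccc(C(=O)NN(C(=O)c2ccccc2Cl)C(C)(C)C)cc1` gives 51.3 nM in this assay. Going by the values given here, the only step available, a 1.0-fold lower number from compound 1 to compound 2 (0.01 log units; within the scatter), shows that moving the methoxy group around the ring left the number essentially unchanged. Compound 2 therefore has the lowest of the two numbers, but its gap to compound 1 lies within the scatter, so the two cannot be ranked.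

Compound 3 `Cc1cccc(C(=O)NN(C(=O)c2ccccc2Cl)C(C)(C)C)c1C` has not yet been measured. It differs from compound 2 in one place: 2,3-dimethylphenyl in place of 4-methoxyphenyl on a carbonyl carbon. Among the compounds with values here, no measured step touches a dimethylphenyl ring or the loss of the methoxy oxygen, so the single step from compound 1 to compound 2 bears on this change only loosely, by showing that the ring pattern on this carbonyl carbon tolerated one rearrangement without effect. For compound 3 a step of a 1.6-fold higher number from compound 2 to compound 3 (0.19 log units; within the scatter) is expected, most likely a small move toward a higher number, with wide uncertainty. The estimate for compound 3 in this assay is 80 nM, within a range from 25 nM to 300 nM.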

Compound 3, half-maximal effective concentration: 20 nM
Estimate against measurement, compound 3: 4.0-fold (0.60 log units) above, and the stated range ends above it.
By their numbers in this assay, from the lowest: compound 3; then compounds 2 and 1 (each within the scatter of the next).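

In this assay, going by these compounds alone, putting 2,3-dimethylphenyl in place of either methoxyphenyl ring on this carbonyl carbon produces the first change beyond the scatter at this position: a 2.6-fold lower number from compound 2 to compound 3 (0.41 log units; beyond the scatter), and a 2.6-fold lower number from compound 1 to compound 3 (0.42 log units; beyond the scatter). Moving the methoxy group had left the number unchanged within the scatter, so the new result adds something: this position does respond to what the ring carries, at least for this replacement, and here the modest shift means that less compound is needed. The entering and leaving groups have the same heavy-atom count, but the entering group has no hydrogen-bond acceptor where the leaving group has one, and nothing available explains why the number moved.

The compounds shown cannot separate the loss of the methoxy oxygen from the arrival of the dimethyl pattern, since a ring with a single methyl group, such as 3-methylphenyl, is not among them. They also leave open how the number would respond to a ring on this carbonyl carbon that carries an amine or a carboxylic acid.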